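Aryl change on the shared core, compound 2 to compound 3

This account rests on a few compounds, and the source may have more. Where it says the series, first, only, none or still open, it means among the compounds named here.

Measured so far in a functional assay on HepG2 cells (Homo sapiens) for inhibition, read by CCK-8 assay, with a stated time of 48 h; a lower number here means a stronger inhibitor, a higher number a weaker inhibitor
compound 1 `O=C1CSC(N2N=C(c3ccc(F)cc3)CC2c2ccc3ccccc3c2)=N1` gives 24100 nM
compound 2 `Cc1ccc(C2=NN(C3=NC(=O)CS3)C(c3ccc4ccccc4c3)C2)cc1C` gives 8490 nM

Compound 2 holds the lower of the two numbers. Compound 3 `O=C1CSC(N2N=C(c3ccc(Cl)cc3)CC2c2ccc3ccccc3c2)=N1` brings 4-chlorophenyl in place of 3,4-dimethylphenyl on a carbon with a double bond to nitrogen with 4-chlorophenyl in place of 3,4-dimethylphenyl on a carbon with a double bond to nitrogen. Within the data shown here, the only measured step bearing on this is a 2.8-fold lower number from compound 1 to compound 2 (0.45 log units; beyond the scatter) at the same place, modest and with 3,4-dimethylphenyl entering. Its loss here should therefore give a modest rise in this assay of similar or smaller size. For compound 3 the estimated value is 18000 nM with an expected range of 7500 nM to 40000 nM in this assay. That means an expected 2.1-fold higher number from compound 2 to compound 3 (0.33 log units; beyond the scatter) in all.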

Compound 3, half-maximal inhibitory concentration: 20400 nM
Beside the measured number, compound 3's estimate is 1.1-fold (0.05 log units) below it; measured number inside the range.
By their numbers in this assay, from the lowest: compound 2; then compounds 3 and 1 (each within the scatter of the next).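

In this assay the step to 4-chlorophenyl (a 2.4-fold higher number from compound 2 to compound 3 (0.38 log units; beyond the scatter)) shows that the advantage of 3,4-dimethylphenyl at this position is not limited to the comparison with the fluoro compound. The exchange of halogen on the aromatic carbon (a 1.2-fold lower number from compound 1 to compound 3 (0.07 log units; within the scatter)) stays within the scatter, so these two halogens are not separated here. No supporting measurement explains either step.

The compounds shown leave open whether a single methyl would keep the advantage of 3,4-dimethylphenyl. They also leave open how a methoxy group, an amine or a carboxylic acid on this phenyl ring would compare.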